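Shifting the Furan Attachment on a Shared Core

The source may hold more compounds than are shown below. What is called first, only, known or untested is meant among the compounds shown, and "the series" means these compounds.

Compound 2 `CCCOC(=O)C1=C(C)N(C)C(=O)NC1c1ccco1` was tested in an assay on membranes from HEK293 cells for displacement of a labelled ligand from adenosine receptor A2b (Homo sapiens), read by scintillation counting, with a stated time of 30 min, tested at 1 uM (a higher number here means more inhibition at the concentration tested (going by the name of the read-out), a lower number less inhibition), where compound 2 gives 23%. Of the two numbers available it is the lowest, with compound 1 `COC(=O)C1=C(C)N(C)C(=O)NC1c1ccco1` nearest: in this assay compound 1 gives 31%, and the step of a number 8 percentage points lower from compound 1 to compound 2 (within the scatter) lies within the scatter. Compound 3 `CCCOC(=O)C1=C(C)N(C)C(=O)NC1c1ccoc1` has not yet been measured. It differs from compound 2 by furan-3-yl in place of furan-2-yl on a saturated ring carbon. Going by the values given here, the single measured step, a number 8 percentage points lower from compound 1 to compound 2 (within the scatter), concerns the ester chain and not the furan, so no measured step bears on this change, and the data offer no guidance on what moving the attachment of the furan does. Compound 3 is therefore expected to show no step beyond the scatter in this assay, an expected no change at the digits printed from compound 2 to compound 3 (within the scatter). Compound 3 is estimated at 23%, within a range from 5% to 42%.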

Compound 3, a percentage reported as inhibition, at one concentration (the size of the read-out at that concentration, not a potency): 2%
For compound 3 the middle estimate is 21 percentage points above the measured one; the whole stated range lies above it.
By their numbers in this assay, from the lowest: compound 3; then compounds 2 and 1 (each within the scatter of the next).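

In this assay, moving the attachment of the furan on the saturated ring carbon gives a number 21 percentage points lower from compound 2 to compound 3 (beyond the scatter), even though furan-2-yl and furan-3-yl have the same atoms and the same printed counts. The earlier change on the ester chain, a number 8 percentage points lower from compound 1 to compound 2 (within the scatter), is the only other step shown, so the furan attachment is the first place in this series where a single change goes beyond the scatter. No measurement at hand accounts for the difference between the two attachments.

The compounds shown leave open whether furan-3-yl gives a similar step when the ester is the methyl ester of compound 1 rather than the propoxycarbonyl group of compound 2. They also leave open how a phenyl or thiophene ring would read at this same ring carbon, or a furan carrying an amine.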